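A few compounds are considered here, and "the series" means these few. Any claim that something is new, unique, unknown or untested is made for them only; others in the source may bear on it.

The compounds share one core, carried by compound 1 `C(=C/C1CCCCC1)\c1nc2cc(-c3ccccc3)ccc2[nH]1`, compound 2 `Fc1ccccc1-c1ccc2[nH]c(/C=C/C3CCCCC3)nc2c1` and compound 3 `Clc1ccccc1-c1ccc2[nH]c(/C=C/C3CCCCC3)nc2c1`. In an ADME assay on microsomes from liver (Canis lupus familiaris) for metabolic stability, with a stated time of 10 min (on this read-out lower numbers stand for a less stable compound and higher numbers for a more stable compound), compound 2 gives 75%. For compound 3 the entry in this assay reads "not determined" (no result reported), and for compound 1 the entry reads "not determined" (no result reported), so compound 3 stands without a measured anchor of its own. Compound 4 `Cc1ccccc1-c1ccc2[nH]c(/C=C/C3CCCCC3)nc2c1` differs from compound 3 by methyl in place of chloro on an aromatic carbon. Among the measured compounds shown here, no step between measured compounds is available to size this change, and the expectation in this assay is a step no larger than the usual scatter, in no firm direction. Compound 4 is expected to give 68%, with a range from 45% to 90%.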

Compound 4, percent of the compound remaining: 13%
Compound 4: middle estimate off by 55 percentage points, on the high side, outside the stated range (below it).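

With methyl in place of fluoro on the aromatic carbon ortho to a large group, this assay shows a number 62 percentage points lower from compound 2 to compound 4 (beyond the scatter), so this position is not indifferent to a swap of one small group for another. The earlier compounds shown here gave no step at all to show this. Nothing at hand explains the drop.

As far as these compounds go, with no number for compound 3 or compound 1, it stays open how chloro or an unsubstituted phenyl compares with these two groups. Also open, from the compounds shown here alone, is what a methoxy group or an amine would give at this position.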